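Swapping a Chain-End Methyl for Chlorine on Compound 1

The source may report more compounds than this note shows. Statements on the series, on what has been measured and on what is new or still open speak of the compounds shown alone.

Measured so far:
- compound 1, `CCCC(=O)Nc1ccc(S(=O)(=O)Oc2ccccc2C(C)C)cc1`: 950 nM
- compound 2, `CCCC(=O)Nc1ccc(S(=O)(=O)Oc2ccccc2I)cc1`: 2000 nM
- compound 3, `CC(C)C(=O)Nc1ccc(S(=O)(=O)Oc2ccccc2I)cc1`: 3300 nM

These three compounds were tested in a functional assay on HT-1080 cells (Homo sapiens) for antiproliferative activity, read by sulforhodamine B assay, with a stated time of 48 h; a lower number here means a stronger inhibitor, a higher number a weaker inhibitor. Among them, compound 1 gives the lowest number, 950 nM; the nearest is compound 2 at 2000 nM, and the furthest is compound 3 at 3300 nM.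

The next compound, compound 4, `CC(C)c1ccccc1OS(=O)(=O)c1ccc(NC(=O)CCCl)cc1`, differs from compound 1 in one place: chloro in place of methyl on a saturated chain carbon, two bonds along the chain from a carbonyl carbon.

Neither measured step matches this change directly. The step of a 2.1-fold higher number from compound 1 to compound 2 (0.32 log units; beyond the scatter) concerns a substituent on the aromatic ring, not the chain, and the step of a 1.7-fold higher number from compound 2 to compound 3 (0.22 log units; within the scatter) changes the shape of the acyl chain yet stays within the scatter. The chain that is altered in compound 4 is the same chain altered from compound 2 to compound 3, where the number hardly moved. For compound 4 the expected step in this assay is therefore a 1.1-fold higher number from compound 1 to compound 4 (0.02 log units; within the scatter), which is to say no change beyond the scatter in either direction.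

The estimate for compound 4 in this assay is 1000 nM, with a range from 400 nM to 2500 nM.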

Compound 4, half-maximal inhibitory concentration: 6500 nM
Beside the measured number, compound 4's estimate is 6.5-fold (0.81 log units) below it; the measured number lies above the stated range.
By their numbers in this assay, from the lowest: compound 1; then compounds 2, 3 and 4 (each within the scatter of the next, the first and the last beyond it).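

In this assay, for the compounds shown here, the acyl chain proves far less forgiving than the earlier compounds suggested: chloro in place of methyl on a saturated chain carbon, two bonds along the chain from a carbonyl carbon, gives a 6.8-fold higher number from compound 1 to compound 4 (0.84 log units; beyond the scatter) and this step lies beyond the scatter. Going by these compounds alone, the only earlier change to this chain, a 1.7-fold higher number from compound 2 to compound 3 (0.22 log units; within the scatter) and so within the scatter, gave no sign of this, so a change of one heavy atom at the chain end can matter even though reshaping the chain near the carbonyl did not. No measurement shown here accounts for the size of this step.

On these data alone, whether the weakening belongs to chloro itself or to any replacement of that methyl stays open, and a fluoro, a hydroxyl or an amine in its place would help to separate the two. Also open, as far as these compounds go, is whether the 2-chloroethyl chain would give a similar step on the iodo compound 2.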